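Series notes: methyl position on the shared core

A few compounds are considered here, and "the series" means these few. Any claim that something is new, unique, unknown or untested is made for them only; others in the source may bear on it.

Compound 1 `Cc1cc2[nH]nc(N)c2c(=O)[nH]1` is the reference in an assay on isolated protein for inhibition of RAC-beta serine/threonine-protein kinase (Homo sapiens), read by mobility shift assay, tested at 30 uM; on this read-out higher numbers stand for more inhibition at the one concentration tested (going by the name of the read-out) and lower numbers for less inhibition; compound 1 gives 8%, the highest of the three numbers, though the other two lie within the scatter of it. Compound 2 `Nc1n[nH]c2cc(-c3cccs3)[nH]c(=O)c12` gives 5% and compound 3 `CC(C)(C)c1cc2[nH]nc(N)c2c(=O)[nH]1` gives 4%. The three steps among them, a number 3 percentage points lower from compound 1 to compound 2 (within the scatter), a number 4 percentage points lower from compound 1 to compound 3 (within the scatter) and a number 1 percentage points lower from compound 2 to compound 3 (within the scatter), all exchange the group on the same aromatic carbon and none of them moves the read-out beyond the scatter.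

Compound 4 `Nc1n[nH]c2cc(CC3CCNCC3)[nH]c(=O)c12` is not yet measured. It differs from compound 1 by piperidin-4-yl in place of hydrogen on a saturated chain carbon bound to an aromatic carbon. The relevant precedent is the three steps above: changing what sits on that aromatic carbon, whether to thiophen-2-yl or tert-butyl, left inhibition low and flat. Extending the methyl by a piperidin-4-yl is a different kind of change, but nothing in the data suggests a step beyond the scatter in either direction. Compound 4 is therefore expected to give about 8%, in the range 0% to 22%, a step of no change at the digits printed from compound 1 to compound 4 (within the scatter) that is expected to stay within the scatter.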

Compound 4, a percentage reported as inhibition, at one concentration (the size of the read-out at that concentration, not a potency): 6%
Compound 4: middle estimate off by 2 percentage points, on the high side; the range from low to high includes it.
By their numbers in this assay, from the lowest: compounds 3, 2, 4 and 1 (each within the scatter of the next).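

In this assay the change to piperidin-4-yl on a saturated chain carbon bound to an aromatic carbon gives a number 2 percentage points lower from compound 1 to compound 4 (within the scatter) and so does not lift the read-out beyond the scatter. The earlier steps shown here exchanged only the group on the aromatic carbon itself, whereas this one extends outward from that carbon and brings in a six-membered non-aromatic ring with a hetero atom, and the read-out still stays flat. No supporting data bear on why this change leaves the number within the scatter.

From the compounds shown here alone, whether a carboxylic acid, a longer chain ending in an amine, or a substituent on the piperidine nitrogen would give a step beyond the scatter remains open. Going by these compounds, with a single concentration per compound, potency across the series also remains open.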